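Swapping the aromatic group on the thiazole-bearing core

The compounds below may be only part of what the source reports. "The series", "measured", "known", "first", "only" and "open" are said of these compounds alone.

Of the compounds shown here, three of one series have been measured so far, all in a functional assay on BJAB cells (Homo sapiens) for antiproliferative activity, with a stated time of 4 days; on this read-out higher numbers stand for an effect only at larger amounts of compound and lower numbers for an effect already at smaller amounts. Compound 1 `COc1ccc(-c2c(C)nn(-c3nc(-c4ccc(Cl)c(Cl)c4)c(SC(C)C)s3)c2C(=O)O)cc1` gives 2100 nM in this assay. Compound 2 `Cc1c(-c2cc(Cl)cc(Cl)c2)c(C(=O)O)nn1-c1nc(-c2ccncc2)c(SC(C)C)s1` is reported as "not active" (no number reported) in this assay, with no number attached. Compound 3 `Cc1c(-c2cc(Cl)cc(Cl)c2)c(C(=O)O)nn1-c1nc(-c2ccc3nccn3c2)c(SC(C)C)s1` is likewise reported as "not active" (no number reported) in this assay, again without a number. Going by the values given here, compound 3 therefore stands without a single value, and it shares this outcome with one further compound; with no two numbers to compare, no step between measured compounds can be worked out.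

Compound 4 `Cc1c(-c2cc(Cl)cc(Cl)c2)c(C(=O)O)nn1-c1nc(-c2cnn(C)c2)c(SC(C)C)s1` has not yet been measured. It keeps the core of compound 3 and differs in one place: a group of 6 heavy atoms (4 carbon, 2 nitrogen; one five-membered aromatic ring with 2 hetero atoms) in place of a group of 9 heavy atoms (7 carbon, 2 nitrogen; one five-membered aromatic ring with 2 hetero atoms, one six-membered aromatic ring with 1 hetero atom), on an aromatic carbon

Among the compounds with values here, there is no measured pair on which to size this change, so the expected step in this assay can only be judged from the two compounds that share the core with compound 4, compound 2 and compound 3, neither of which shows activity. A move beyond the usual scatter toward activity is not expected. Compound 4 is therefore estimated to give about 15000 nM, within a range from 4000 nM to 60000 nM, and the most likely outcome is that this assay again reports no activity rather than a number.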

Compound 4, half-maximal effective concentration: "not active" (no number reported)
No number was reported for compound 4; the estimate stays without a comparison.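

In this assay compound 3 and compound 4 are both reported as not active, without a number, so no step can be read from placing 1-methyl-1H-pyrazol-4-yl on the shared core. Nothing further here bears on this result. On these data alone, whether any group in this place gives a measurable effect on this core stays open.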